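The source may report more compounds than this note shows. Statements on the series, on what has been measured and on what is new or still open speak of the compounds shown alone.

Measured so far in a functional assay on aorta (VSMC cells, Rattus norvegicus); on this read-out lower numbers stand for an effect already at smaller amounts and higher numbers for an effect only at larger amounts of compound:
- compound 1 `O=S1(=O)N=C(SCc2ccccc2)Nc2ccc(Cl)cc21` gives 5400 nM
- compound 2 `CC(C)SC1=NS(=O)(=O)c2cc(Cl)ccc2N1` gives 23000 nM

For the measured compounds named here, of these two numbers, compound 2 holds the higher, and compound 1 is its only neighbour. The next compound is compound 3 `CC(SC1=NS(=O)(=O)c2cc(Cl)ccc2N1)c1ccccc1`, whose difference from compound 2 is phenyl in place of methyl on a saturated chain carbon bound to a saturated chain carbon and a sulfur.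

Going by the values given here, only one measured step bears on this change. Compound 1 carries a benzyl group on the sulfur, and the step with isopropyl in place of benzyl is a 4.3-fold higher number from compound 1 to compound 2 (0.63 log units; beyond the scatter), modest but beyond the scatter. Compound 3 again has a phenyl on the carbon bound to the sulfur, so a modest move of about that size in the opposite direction, towards a lower number, is expected in this assay. Among the compounds with values here, no measured compound has phenyl and methyl together on that carbon, so the range stays wide. The expected step is a 3.5-fold lower number from compound 2 to compound 3 (0.55 log units; beyond the scatter) as an estimate. The estimated value for compound 3 is 6500 nM (expected range 2200 nM to 19000 nM).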

Compound 3, half-maximal effective concentration: 5400 nM
Beside the measured number, compound 3's estimate is 1.2-fold (0.08 log units) above it, within the range that was stated.
By their numbers in this assay, from the lowest: compounds 1 and 3 (each within the scatter of the next); then compound 2.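

In this assay, phenyl in place of methyl on a saturated chain carbon bound to a saturated chain carbon and a sulfur gives a 4.3-fold lower number from compound 2 to compound 3 (0.63 log units; beyond the scatter) and so matches in size the step between the benzyl and isopropyl compounds, now with a methyl kept on that carbon. Methyl in place of hydrogen on a saturated chain carbon bound to an aromatic carbon and a sulfur gives no change at the digits printed from compound 1 to compound 3 (within the scatter) and so leaves no readable effect of the added methyl in this pair, which means that among these three compounds the lower numbers go with the phenyl and compound 2 alone lacks it. No available data give a reason for either step.

Still open, on these data alone, is whether another group on that carbon, such as cyclohexyl, a pyridine ring or a longer chain, would keep the number of compound 3 or shift it. The same holds for a phenyl carrying an amine or a carboxylic acid, and for any change to the shared core, which stays the same in all three compounds.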